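The compounds below may be only part of what the source reports. "The series", "measured", "known", "first", "only" and "open" are said of these compounds alone.

Of the compounds shown here, three that share one core have been tested in an ADME assay on L02 cells (Homo sapiens) for cytotoxicity, read by MTT assay, with a stated time of 48 h; on this read-out lower numbers stand for stronger inhibition and higher numbers for weaker inhibition. Compound 1 `O=C1O[C@@H](CN2CCC(c3ccc(F)cc3)CC2)CN1c1ccc(-n2cc(-c3ccccn3)cn2)c(F)c1` gives only a limit of the assay, > 400 ug/mL. Compound 2 `COC[C@H]1CN(c2ccc(-n3cc(-c4ccccn4)cn3)c(F)c2)C(=O)O1` likewise gives only a limit, > 400 ug/mL. Among the measured compounds shown here, compound 3 `O=C1O[C@@H](Cn2ccnc2)CN1c1ccc(-n2cc(-c3ccccn3)cn2)c(F)c1` is the sole compound with a number, reading 350 ug/mL in this assay. Compound 3 therefore stands alone with a number. For the measured compounds named here, the single step between measured compounds, an at least 1.1-fold lower number from compound 2 to compound 3 (0.05 log units; that floor lies within the scatter), puts 1H-imidazol-1-yl in place of methoxy on a saturated chain carbon bound to a saturated ring carbon, and its size cannot be read more closely than the limit allows (the limit of > 400 ug/mL in this assay, at which 2 of the 3 values shown sit). Compound 4 `O=C(NC[C@H]1CN(c2ccc(-n3cc(-c4ccccn4)cn3)c(F)c2)C(=O)O1)C(F)F` carries a new group at that same place: ((difluoromethyl)carbonyl)amino in place of 1H-imidazol-1-yl on a saturated chain carbon bound to a saturated ring carbon. Going by the values given here, no measured step shows this exact exchange; the one step at this position was small, within the scatter. The expected step is therefore a 1.1-fold higher number from compound 3 to compound 4 (0.06 log units; within the scatter), in no clear direction beyond the scatter. Compound 4 is estimated at 400 ug/mL in this assay, between 200 ug/mL and 800 ug/mL, with a real chance that only a limit is reported.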

Compound 4, half-maximal inhibitory concentration: > 400 ug/mL
Compound 4: a limit, no number (the forecaster's own chance of this, stated with the estimate: 55%); the middle value lies on the limit itself.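

In this assay, the step to the new group, with no ring and one hydrogen-bond donor in place of the five-membered aromatic ring, is an at least 1.1-fold higher number from compound 3 to compound 4 (0.05 log units; that floor lies within the scatter). Compound 4 gives only a limit, > 400 ug/mL. The step from compound 2 to compound 4 cannot be read, and the step above cannot be sized more closely, because the values stop at the limit: the limit of > 400 ug/mL in this assay, at which 3 of the 4 values shown sit.

With a single number in the set, the compounds shown leave open whether any group at this place can move the reading beyond the scatter. From the compounds shown here alone, how a primary amine or a carboxylic acid on this saturated chain carbon would read also stays open, and so does whether the two fluorines of ((difluoromethyl)carbonyl)amino matter to the reading.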